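A methyl on the aromatic ring of compound 1

The source may report more compounds than this note shows. Statements on the series, on what has been measured and on what is new or still open speak of the compounds shown alone.

- Compound 1 `CCCN1C(=O)COc2cc(CNc3ccccc3)ccc21` gives 10100 nM as its value
- Compound 2 `CCCCN1C(=O)COc2cc(CNc3ccccc3)ccc21` gives 15200 nM as its value

In a functional assay on a cell-free system (Platelet, plasma, Oryctolagus cuniculus) for inhibition, with stated times of 5 min and 6 min (on this read-out higher numbers stand for weaker inhibition and lower numbers for stronger inhibition), compound 1 gives 10100 nM and compound 2 gives 15200 nM on the same scale, so the two cannot be told apart and compound 1 holds no distinct place. Compound 3 `CCCN1C(=O)COc2cc(CNc3ccccc3C)ccc21` differs from compound 1 elsewhere, with methyl in place of hydrogen on an aromatic carbon — a methyl in place of hydrogen on an aromatic carbon, or phenyl to 2-methylphenyl. Going by the values given here, the only measured step is a 1.5-fold higher number from compound 1 to compound 2 (0.18 log units; within the scatter) and it also adds a methyl, but on a saturated chain carbon. Among the compounds with values here, no step at an aromatic carbon has been measured, so it is only a weak guide. Nothing beyond the scatter is therefore expected in this assay and no direction is favoured. For compound 3 the estimate is 12000 nM with an expected range of 5000 nM to 30000 nM on this scale. The estimated step is a 1.2-fold higher number from compound 1 to compound 3 (0.07 log units; within the scatter) at the middle of that range.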

Compound 3, half-maximal inhibitory concentration: 18800 nM
The estimate for compound 3 lay 1.6-fold (0.19 log units) below the measured number; measured number inside the range.
By their numbers in this assay, from the lowest: compounds 1, 2 and 3 (each within the scatter of the next).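

In this assay, putting a methyl on an aromatic carbon, ortho to a large group, gives a 1.9-fold higher number from compound 1 to compound 3 (0.27 log units; within the scatter) and so does not separate the two compounds. This position therefore accepts the change from phenyl to 2-methylphenyl without a clear gain or loss of inhibition, just as the added methyl on the saturated chain gave a 1.5-fold higher number from compound 1 to compound 2 (0.18 log units; within the scatter) and stayed within the scatter as well. Nothing measured here bears on why the number falls where it does.

Going by these compounds, whether a single methyl is simply too small a change to register remains unknown, since a methoxy group, a chlorine atom, an amine or a carboxylic acid at this place could behave differently. On these data alone, the effect of a methyl on the other carbons of this aromatic ring is also still open.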